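Methyl in Place of Methoxy on the Nucleoside Core

A few compounds are considered here, and "the series" means these few. Any claim that something is new, unique, unknown or untested is made for them only; others in the source may bear on it.

Measured compounds in a functional assay on K562 cells (Homo sapiens), read by MTT assay, with a stated time of 72 h; a lower number here means a stronger inhibitor, a higher number a weaker inhibitor:
compound 1, `C#Cc1cn([C@@H]2O[C@H](CO)[C@@H](O)[C@H]2O)c2ncnc(OC)c12`: 380 nM
compound 2, `COc1ncnc2c1c(-c1ccsc1)cn2[C@@H]1O[C@H](CO)[C@@H](O)[C@H]1O`: 3450 nM
compound 3, `COc1ncnc2c1c(-c1ccoc1)cn2[C@@H]1O[C@H](CO)[C@@H](O)[C@H]1O`: 2820 nM

Compound 1 gives the lowest number of the three and is the strongest inhibitor among them, since the steps of a 9.1-fold higher number from compound 1 to compound 2 (0.96 log units; beyond the scatter) and a 7.4-fold higher number from compound 1 to compound 3 (0.87 log units; beyond the scatter) both lie beyond the scatter. Between the two ring replacements, the step of a 1.2-fold lower number from compound 2 to compound 3 (0.09 log units; within the scatter) lies within the scatter. Compound 4, `C#Cc1cn([C@@H]2O[C@H](CO)[C@@H](O)[C@H]2O)c2ncnc(C)c12`, differs from compound 1 in one place: methyl in place of methoxy on an aromatic carbon. For the measured compounds named here, none of the measured steps touches this position; all three concern the ethynyl group, where replacing it by a five-membered aromatic ring raised the number modestly. The data therefore carry no direct guide for the methyl-for-methoxy change, and a step of no more than modest size, in either direction, seems the fairest expectation. In this assay compound 4 is estimated at 700 nM, with a range from 150 nM to 3500 nM. This estimate corresponds to an expected 1.8-fold higher number from compound 1 to compound 4 (0.27 log units; within the scatter).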

Compound 4, half-maximal inhibitory concentration: 110 nM
Compound 4: the middle estimate sits 6.4-fold (0.80 log units) above what was measured; measured number outside the range, below it.
By their numbers in this assay, from the lowest: compound 4; then compound 1; then compounds 3 and 2 (each within the scatter of the next).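

In this assay, for the compounds shown here, the position next to the ring nitrogen proved sensitive to substitution, which the earlier compounds, all carrying methoxy there, could not show: the change to methyl gives a 3.5-fold lower number from compound 1 to compound 4 (0.54 log units; beyond the scatter). Going by these compounds alone, with the ethynyl group held constant, this step is beyond the scatter and makes the methoxy oxygen, with its hydrogen-bond acceptor, unnecessary for inhibition in this pair, so the ethynyl group is not the only place where the number responds. Nothing available explains why the number falls with this change.

From the compounds shown here alone, whether methyl brings a similar step when thiophen-3-yl or furan-3-yl replaces ethynyl remains open. Also open, going by these compounds, is how an amine, a chlorine atom or a longer chain such as ethyl would fare on this aromatic carbon.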